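The source may hold more compounds than are shown below. What is called first, only, known or untested is meant among the compounds shown, and "the series" means these compounds.

Three compounds were measured in an assay on CHO cells for displacement of a labelled ligand from adenosine receptor A1 (Homo sapiens), read by scintillation counting, with a stated time of 120 min, tested at 10 uM; on this read-out higher numbers stand for more inhibition at the one concentration tested (going by the name of the read-out) and lower numbers for less inhibition:

compound 1 `Nc1scc(CN2CCN(c3ccc(F)cc3Cl)CC2)c1C(=O)c1ccc(Cl)cc1`: 0%
compound 2 `Nc1scc(CN2CCN(c3ccc(OC(F)(F)F)cc3)CC2)c1C(=O)c1ccc(Cl)cc1`: 0%
compound 3 `Nc1scc(CN2CCN(c3cccc4ccccc34)CC2)c1C(=O)c1ccc(Cl)cc1`: 1%

Compound 2 stands level with compound 1 in this assay, and both sit at the floor of the read-out; its nearest neighbour is compound 1, no change at the digits printed from compound 1 to compound 2 (within the scatter), and its furthest is compound 3, a number 1 percentage points higher from compound 2 to compound 3 (within the scatter). The remaining pair behaves the same way: a number 1 percentage points higher from compound 1 to compound 3 (within the scatter). All three differ from one another only in the aryl group on the amine nitrogen in the ring, and none of these exchanges moved the number beyond the scatter.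

Compound 4 `Nc1scc(CN2CCN(c3cccc(Cl)c3)CC2)c1C(=O)c1ccc(Cl)cc1` is the next member of the series. Its difference from compound 2 is 3-chlorophenyl in place of 4-(trifluoromethoxy)phenyl on an amine nitrogen in a ring. This is the same kind of exchange as the three measured steps, each of which stayed within the scatter, so no change beyond the scatter is expected here either; the expected step is a number 1 percentage points higher from compound 2 to compound 4 (within the scatter). Compound 4 is therefore estimated to give 1% in this assay, with a range from 0% to 8%.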

Compound 4, a percentage reported as inhibition, at one concentration (the size of the read-out at that concentration, not a potency): 0%
Estimate against measurement, compound 4: 1 percentage points above, within the range that was stated.
By their numbers in this assay, from the lowest: compounds 1, 2, 4 and 3 (each within the scatter of the next).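

In this assay, the exchange to 3-chlorophenyl gives no change at the digits printed from compound 2 to compound 4 (within the scatter), and the same group compared with the other two aryl groups gives no change at the digits printed from compound 1 to compound 4 (within the scatter) and a number 1 percentage points lower from compound 3 to compound 4 (within the scatter). This extends the flat picture at the amine nitrogen to a phenyl group with a single chlorine, which has 7 heavy atoms and 0 hydrogen-bond acceptors, against 11 heavy atoms and 1 hydrogen-bond acceptor in the 4-(trifluoromethoxy)phenyl it replaces, so neither of these differences moved the number beyond the scatter. Nothing available explains why the number stays at this level across these aryl groups.

From the compounds shown here alone, all four compounds carry a carbon-only aromatic ring on this nitrogen, so it remains open whether a pyridine ring, a saturated group such as cyclohexyl, or a phenyl ring bearing a carboxylic acid or an amine would lift the number. Going by these compounds, with the shared core the same throughout, it is also open whether exchanges at this position would stay this silent on a core that reads well above the floor of the read-out.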